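This account rests on a few compounds, and the source may have more. Where it says the series, first, only, none or still open, it means among the compounds named here.

Compound 1 `CC(=O)c1ccc(OCc2cccc(C)c2)cc1` gives the lower of the two measured numbers in an assay on isolated protein for inhibition of Amine oxidase [flavin-containing] A (Homo sapiens), read by Amplex Red, with a stated time of 15 min, tested at 100 uM; a lower number here means less inhibition, a higher number more inhibition at the concentration tested (going by the name of the read-out): compound 1 gives 32.3%, and its nearest neighbour, compound 2 `CC(=O)c1ccc(OCc2ccc(F)cc2F)cc1`, gives 45.7%, a gap that lies beyond the usual scatter. Compound 3 `CC(=O)c1ccc(OCc2cccc(C(F)(F)F)c2)cc1` has not yet been measured in this assay. It differs from compound 1 in one place: trifluoromethyl in place of methyl on an aromatic carbon. For the measured compounds named here, no measured pair in the set shows the effect of this change, so its size cannot be read from the data; compound 2 differs from compound 1 at several points at once and offers no guide to this one. Compound 3 is expected to give a step that is upward but small, a number 7.7 percentage points higher from compound 1 to compound 3 (within the scatter), not clearly beyond the scatter. Compound 3 is estimated at 40%, with a range from 22% to 60%.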

Compound 3, a percentage reported as inhibition, at one concentration (the size of the read-out at that concentration, not a potency): 48.9%
For compound 3 the middle estimate is 8.9 percentage points below the measured one, within the range that was stated.
By their numbers in this assay, from the lowest: compound 1; then compounds 2 and 3 (each within the scatter of the next).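

In this assay, replacing methyl with trifluoromethyl on this aromatic carbon, meta to a large group, produces a number 16.6 percentage points higher from compound 1 to compound 3 (beyond the scatter). For the compounds shown here, this is the first measured step at this position, and it shows that a group of four heavy atoms can take the place of a single carbon here with a higher, not a lower, number at the tested concentration. No measurement is available that explains the step.

With only methyl and trifluoromethyl compared at this place, the compounds shown leave open whether a chlorine atom, a methoxy group or an amine there would give a higher or lower number. They also leave open whether the same change on another carbon of this ring would give a step of similar size.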